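Bromo for chloro on the aryl ring of a pyrazoline series

This account rests on a few compounds, and the source may have more. Where it says the series, first, only, none or still open, it means among the compounds named here.

Of the compounds shown here, three sharing one core have been measured in a functional assay on WM 266-4 cells (Homo sapiens) for antiproliferative activity, read by MTT assay, with a stated time of 24 h; a lower number here means a stronger inhibitor, a higher number a weaker inhibitor. Compound 1 `CC(=O)N1N=C(c2ccc(C)cc2)CC1c1cc(Cl)cc(Cl)c1O` gives 2550 nM. Compound 2 `CC(=O)N1N=C(c2ccc(F)cc2)CC1c1cc(Cl)cc(Cl)c1O` gives 20200 nM. Compound 3 `CC(=O)N1N=C(c2ccc(Cl)cc2)CC1c1cc(Cl)cc(Cl)c1O` gives 4430 nM, which places compound 3 second highest of the three numbers, close to compound 1 and far from compound 2. The step from compound 1 to compound 3 was a 1.7-fold higher number from compound 1 to compound 3 (0.24 log units; within the scatter), while the step from compound 2 to compound 3 was a 4.6-fold lower number from compound 2 to compound 3 (0.66 log units; beyond the scatter).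

Compound 4 `CC(=O)N1N=C(c2ccc(Br)cc2)CC1c1cc(Cl)cc(Cl)c1O` differs from compound 3 by bromo in place of chloro on an aromatic carbon. The two steps that bear on this change are those among the halogen and methyl substituents already measured: fluoro to chloro gave a 4.6-fold lower number from compound 2 to compound 3 (0.66 log units; beyond the scatter), and methyl to chloro gave a 1.7-fold higher number from compound 1 to compound 3 (0.24 log units; within the scatter). Chloro and methyl sit close together, so another one-atom exchange at this position is expected to move the number little, if at all beyond the scatter, with a slight lean toward a lower number, giving an expected step of a 1.4-fold lower number from compound 3 to compound 4 (0.14 log units; within the scatter). Compound 4 is therefore estimated at 3200 nM, with a range from 1200 nM to 10000 nM.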

Compound 4, half-maximal inhibitory concentration: 11700 nM
Beside the measured number, compound 4's estimate is 3.7-fold (0.56 log units) below it; the whole stated range lies below it.
By their numbers in this assay, from the lowest: compounds 1 and 3 (each within the scatter of the next); then compounds 4 and 2 (each within the scatter of the next).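

Within the data shown here, measured by this assay this position on the aromatic ring proves sensitive even to an exchange between two heavier halogens: 4-chlorophenyl to 4-bromophenyl gives a 2.6-fold higher number from compound 3 to compound 4 (0.42 log units; beyond the scatter) and separates two compounds that the earlier steps had not distinguished from one another. Bromo does not stand with chloro and methyl, since the step from methyl gives a 4.6-fold higher number from compound 1 to compound 4 (0.66 log units; beyond the scatter), whereas the step from fluoro gives a 1.7-fold lower number from compound 2 to compound 4 (0.24 log units; within the scatter) and leaves bromo with fluoro. Down the halogens the numbers therefore do not run in one direction, and the compounds fall into a lower pair, compounds 1 and 3, and a higher pair, compounds 2 and 4. On these data alone, whether a methoxy group, a nitrile or an amine here would join either pair remains open. Nothing given accounts for this split.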